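Three Hydrazones at the Assay Limit and a Fourth

The source may hold more compounds than are shown below. What is called first, only, known or untested is meant among the compounds shown, and "the series" means these compounds.

Compound 1 `COc1cc(/C=N/Nc2nc(-c3ccccc3)cs2)c(Br)c(Br)c1OC` in an ADME assay on HUVEC cells (Homo sapiens) for inhibition, read by MTT assay, with a stated time of 48 h (on this read-out higher numbers stand for weaker inhibition and lower numbers for stronger inhibition), gives > 100000 nM, which is a limit of the assay and not a number.
Compound 2 `COc1ccccc1-c1csc(N/N=C/c2cc(OC)c(OC)c(Br)c2Br)n1` in this assay gives > 100000 nM, again a limit.
Compound 3 `COc1cc(/C=N/Nc2nc(-c3ccccc3)cs2)cc(Br)c1OC` in this assay gives > 100000 nM, also a limit.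

Compound 1 and compound 2 differ by methoxy in place of hydrogen on an aromatic carbon. The resulting step that the two limits leave unreadable from compound 1 to compound 2 cannot be sized because of the limit of > 100000 nM in this assay, at which 3 of the 3 values shown sit. The cores of compound 1 and compound 3 differ by hydrogen in place of bromo on an aromatic carbon, and the step that the two limits leave unreadable from compound 1 to compound 3 is equally unreadable for the same reason.

Compound 4 `COc1ccccc1-c1csc(N/N=C/c2cc(Br)c(OC)c(OC)c2)n1` awaits measurement. It differs from compound 3 by methoxy in place of hydrogen on an aromatic carbon, the same change as from compound 1 to compound 2, the two place descriptions agreeing word for word. With all three measured values sitting at the limit, compound 4 is expected to give 150000 nM in this assay, with a likely range from 60000 nM to 500000 nM, most probably reported again only as a limit. From compound 3 the expected step is a step that the limit leaves unreadable from compound 3 to compound 4, resting on the unreadable a step that the two limits leave unreadable from compound 1 to compound 2.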

Compound 4, half-maximal inhibitory concentration: > 100000 nM
Compound 4 was reported as a limit (the forecaster's own chance of this, stated with the estimate: 85%); the middle value does not contradict the limit.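

No step can be read from compound 3 to compound 4 or from compound 2 to compound 4, because both ends of each pair are limits and not numbers: (the limit of > 100000 nM in this assay, at which 4 of the 4 values shown sit).

The compounds shown leave open how strongly any of the four inhibits in this assay, and whether either change matters at all.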